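Swapping Phenyl for 4-Methylbenzyl at the Assay Limit

The source may hold more compounds than are shown below. What is called first, only, known or untested is meant among the compounds shown, and "the series" means these compounds.

In a functional assay on SW480 cells (Homo sapiens) for cytotoxicity, read by MTT assay, with a stated time of 48 h (a lower number here means a stronger inhibitor, a higher number a weaker inhibitor), compound 3 `CCOC(=O)[C@]1(C(=O)Nc2ccccc2)C[C@H]1c1cc(OC)c(OC)c(OC)c1` gives > 100000 nM, a limit and not a number. Its mirror image, compound 1 `CCOC(=O)[C@@]1(C(=O)Nc2ccccc2)C[C@@H]1c1cc(OC)c(OC)c(OC)c1`, gives > 100000 nM, also a limit. Compound 3 therefore stands at the limit of > 100000 nM in this assay, at which 2 of the 3 values shown sit.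

Compound 4 `CCOC(=O)[C@]1(C(=O)NCc2ccc(C)cc2)C[C@H]1c1cc(OC)c(OC)c(OC)c1` is made from compound 3 by one change: 4-methylbenzyl in place of phenyl on an amide-type nitrogen.

Going by the values given here, the only measured step, a step that the two limits leave unreadable from compound 1 to compound 3, gives no size to work from, and it concerns configuration rather than this swap. The nearest guide is compound 2 `COc1cc([C@@H]2C[C@]2(CO)C(=O)NCc2ccc(C)cc2)cc(OC)c1OC`, which also carries 4-methylbenzyl and gives a real number, 26800 nM. On the strength of that single value, a move towards stronger inhibition is expected, though it may be modest and could stay hidden at the limit. The expected change is an at least 2.5-fold lower number from compound 3 to compound 4 (0.39 log units; beyond the scatter). For compound 4 the estimated value is 40000 nM, with an expected range of 14000 nM to 100000 nM.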

Compound 4, half-maximal inhibitory concentration: 36400 nM
Compound 4: the middle estimate sits 1.1-fold (0.04 log units) above what was measured; measured number inside the range.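

In this assay, going by these compounds alone, 4-methylbenzyl in place of phenyl on the amide-type nitrogen gives this position its only readable step so far: an at least 2.7-fold lower number from compound 3 to compound 4 (0.43 log units; beyond the scatter). On these data alone, compound 3 gives > 100000 nM, a limit and not a number, so the printed step is a minimum and its full size remains unknown. With 4-methylbenzyl on that nitrogen, ethoxycarbonyl and hydroxymethyl on the saturated ring carbon cannot be told apart: a 1.4-fold higher number from compound 2 to compound 4 (0.13 log units; within the scatter).

As far as these compounds go, the step between the mirror images compound 1 and compound 3 cannot be read, so the role of configuration stays open. From the compounds shown here alone, it also remains open whether the gain comes from the methyl or from the benzyl link, and how a plain benzyl or a phenethyl on the nitrogen, or a carboxylic acid on the saturated ring carbon, would read.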